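A Chloro-for-Fluoro Swap in a Series at the Limit

This account rests on a few compounds, and the source may have more. Where it says the series, first, only, none or still open, it means among the compounds named here.

Three small amide compounds built on a lactone-bearing core have been tested in a functional assay on PC-3 cells (Homo sapiens) for antiproliferative activity, read by MTT assay, with a stated time of 72 h; on this read-out higher numbers stand for weaker inhibition and lower numbers for stronger inhibition. Compound 1 `O=C(CNc1ccccc1F)N[C@H]1CCOC1=O` carries a fluoro group, and in this assay compound 1 gives > 64000 nM, which is a limit of the measurement rather than a number. Compound 3 `O=C(CNc1ccccc1Cl)N[C@H]1CCOC1=O` differs from compound 1 by chloro in place of fluoro on an aromatic carbon. In this assay compound 3 gives > 64000 nM, again a limit. The step that the two limits leave unreadable from compound 1 to compound 3 cannot be sized because of the limit of > 64000 nM in this assay, at which 3 of the 3 values shown sit. Compound 2 `O=C(CNc1ccc(F)cc1)N[C@H]1CCOC1=O` has the same atoms as compound 1 joined differently; how the two cores differ is not broken down here. In this assay compound 2 gives > 64000 nM, once more a limit. Compound 4 `O=C(CNc1ccc(Cl)cc1)N[C@H]1CCOC1=O`, not yet measured, differs from compound 2 by chloro in place of fluoro on an aromatic carbon. This is the same kind of change as from compound 1 to compound 3, but the place is para to a large group rather than ortho to a large group. Compound 4 is expected to show a step that the limit leaves unreadable from compound 2 to compound 4, which rests on a step that the two limits leave unreadable from compound 1 to compound 3 being unreadable. Compound 4 is estimated at 100000 nM, most likely reported again only as a limit.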

Compound 4, half-maximal inhibitory concentration: > 64000 nM
Compound 4: no number, only a limit; the forecaster's own chance of this, stated with the estimate: 85%; the middle value is on the limit's open side.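

No size can be read for the step from compound 2 to compound 4, nor for the matching step from compound 1 to compound 3, since these values are limits rather than numbers: the limit of > 64000 nM in this assay, at which 4 of the 4 values shown sit.

The compounds shown leave open how chloro and fluoro would compare in a member of this series whose activity gives a readable number.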